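The source may report more compounds than this note shows. Statements on the series, on what has been measured and on what is new or still open speak of the compounds shown alone.

Measured so far:
compound 1 `c1ccc([C@H]2CCC[C@@H](CCN3CCCC3)C2)cc1` — 61 nM
compound 2 `CN(C)CC[C@@H]1CCC[C@H](c2ccccc2)C1` — 76 nM

In an assay on membranes from liver for displacement of a labelled ligand from Sigma intracellular receptor 2 (Rattus norvegicus), read by scintillation counting, with a stated time of 120 min (on this read-out lower numbers stand for stronger inhibition and higher numbers for weaker inhibition), compound 1 gives 61 nM and compound 2 gives 76 nM; the step of a 1.2-fold higher number from compound 1 to compound 2 (0.10 log units; within the scatter) keeps the two numbers within the scatter of each other. Compound 3 `c1ccc([C@@H]2CCC[C@@H](CCN3CCCC3)C2)cc1` differs from compound 1 by the two compounds have the same atoms and bonds and differ only in configuration as drawn: 1 of 2 stereo elements differ; a stereocentre at a saturated ring carbon is drawn S in compound 1 and R in compound 3. Among the measured compounds shown here, no measured step concerns a change of configuration, and the single step known, a 1.2-fold higher number from compound 1 to compound 2 (0.10 log units; within the scatter), concerns the amine only, so nothing here bears directly on the change. A modest shift in either direction cannot be ruled out. The step of a 1.6-fold higher number from compound 1 to compound 3 (0.21 log units; within the scatter) is the expectation. Compound 3 is estimated at 100 nM, with a range from 30 nM to 400 nM.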

Compound 3, inhibition constant: 33 nM
The estimate for compound 3 lay 3.0-fold (0.48 log units) above the measured number, and the stated range covers the measured number.
By their numbers in this assay, from the lowest: compounds 3, 1 and 2 (each within the scatter of the next, the first and the last beyond it).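

In this assay, the stereocentre at a saturated ring carbon now has a measured step of its own: a 1.8-fold lower number from compound 1 to compound 3 (0.27 log units; within the scatter). With the pyrrolidin-1-yl chain held constant, drawing this centre S or R gives numbers that this read-out does not separate. The comparison isolates this one centre, with no other change in the structures: the fact that compounds 1 and 3 differ only in the configuration as drawn

Still open, as far as these compounds go, are the second stereocentre and whether configuration at this carbon counts for as little with dimethylamino, a piperidine or a longer chain in place of the present amine.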